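Aryl hydrazone swaps on the shared core

The compounds below may be only part of what the source reports. "The series", "measured", "known", "first", "only" and "open" are said of these compounds alone.

Among the measured compounds shown here, compound 1 `CN(C)CCn1cnnc1-c1cc(Oc2ccc(NC(=O)N/N=C/c3ccc(Cl)cc3Cl)cc2F)ccn1` stands second highest of the three numbers measured so far; in a functional assay on MKN-45 cells (Homo sapiens) for cytotoxicity, read by MTT assay, with a stated time of 72 h (on this read-out lower numbers stand for stronger inhibition and higher numbers for weaker inhibition), compound 1 gives 750 nM. Compound 2 `CN(C)CCn1cnnc1-c1cc(Oc2ccc(NC(=O)N/N=C/c3cccc(Br)c3)cc2F)ccn1` gives 450 nM, and compound 3 `CN(C)CCn1cnnc1-c1cc(Oc2ccc(NC(=O)N/N=C/c3ccc(O)cc3)cc2F)ccn1` gives 820 nM. The steps among them are a 1.7-fold lower number from compound 1 to compound 2 (0.22 log units; within the scatter), a 1.1-fold higher number from compound 1 to compound 3 (0.04 log units; within the scatter) and a 1.8-fold higher number from compound 2 to compound 3 (0.26 log units; within the scatter); none leaves the scatter, so no exchange of the aryl ring on this carbon has yet moved the read-out.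

Compound 4 `CN(C)CCn1cnnc1-c1cc(Oc2ccc(NC(=O)N/N=C/c3cccc(O)c3)cc2F)ccn1` is not yet measured. Relative to compound 1 it carries 3-hydroxyphenyl in place of 2,4-dichlorophenyl on a carbon with a double bond to nitrogen. For the measured compounds named here, the steps that bear on it are the two that start from compound 1, in which a 3-bromophenyl and a 4-hydroxyphenyl each entered without a shift beyond the scatter. Nothing in the series points to a 3-hydroxyphenyl behaving otherwise, so the expected step is a 1.1-fold lower number from compound 1 to compound 4 (0.03 log units; within the scatter), none beyond the scatter. For compound 4 the estimate in this assay is 700 nM, with a range from 350 nM to 1400 nM.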

Compound 4, half-maximal inhibitory concentration: 1370 nM
The estimate for compound 4 lay 2.0-fold (0.29 log units) below the measured number, and the stated range covers the measured number.
By their numbers in this assay, from the lowest: compounds 2, 1, 3 and 4 (each within the scatter of the next, the first and the last beyond it).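

In this assay this position now shows its first step beyond the scatter, though a modest one: hydroxy in place of bromo on an aromatic carbon (a 3.0-fold higher number from compound 2 to compound 4 (0.48 log units; beyond the scatter)). Among the compounds shown here, the other two new steps stay within the scatter, both 3-hydroxyphenyl in place of 2,4-dichlorophenyl (a 1.8-fold higher number from compound 1 to compound 4 (0.26 log units; within the scatter)) and 3-hydroxyphenyl in place of 4-hydroxyphenyl (a 1.7-fold higher number from compound 3 to compound 4 (0.22 log units; within the scatter)), so this position responds only in the single comparison of compound 2 with compound 4, and compounds 1 and 3 lie within the scatter of both. No measurement at hand speaks to what lies behind this step.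

As far as these compounds go, it remains open whether a methoxy or an amine in place of the bromo on that aromatic carbon would give a number closer to compound 2 or to compound 4. A carboxylic acid on the aryl ring is likewise an open case.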